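Swapping Methoxy for Fluoro on Compound 2

This account rests on a few compounds, and the source may have more. Where it says the series, first, only, none or still open, it means among the compounds named here.

In a functional assay on HepG2 cells (Homo sapiens) for inhibition, read by MTT assay (a higher number here means a weaker inhibitor, a lower number a stronger inhibitor), compound 1 `O=C(COc1ccc(C(=O)/C=C/c2ccccc2)cc1)NO` gives 620 nM and compound 2 `COc1ccc(/C=C/C(=O)c2ccc(OCC(=O)NO)cc2)cc1` gives 620 nM. Within the data shown here, these two are level and together hold the lowest of the three numbers measured so far. Compound 3 `CC(C)=CCC/C(C)=C/CC/C(C)=C/CSc1ccccc1C(=O)NCCC(=O)NO`, a structure of a different kind, gives 4930 nM, a clearly higher number than compound 2.

The next compound to be measured is compound 4 `O=C(COc1ccc(C(=O)/C=C/c2ccc(F)cc2)cc1)NO`. It differs from compound 2 in one place, with fluoro in place of methoxy on an aromatic carbon. Among the measured compounds shown here, one measured step bears on this carbon: methoxy in place of hydrogen, which gave no change at the digits printed from compound 1 to compound 2 (within the scatter). For the measured compounds named here, no compound carrying fluoro has been measured yet, so this single step is thin evidence. On the strength of it, no step beyond the scatter is expected in this assay. The estimated step is a 1.0-fold lower number from compound 2 to compound 4 (0.01 log units; within the scatter). For compound 4 the expected value is 600 nM, with an estimated range from 250 nM to 1500 nM.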

Compound 4, half-maximal inhibitory concentration: 620 nM
Compound 4: the middle estimate sits 1.0-fold (0.01 log units) below what was measured, and the stated range covers the measured number.
By their numbers in this assay, from the lowest: compounds 1, 2 and 4 (each within the scatter of the next); then compound 3.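

In this assay, fluoro in place of methoxy gives no change at the digits printed from compound 2 to compound 4 (within the scatter), and fluoro in place of hydrogen gives no change at the digits printed from compound 1 to compound 4 (within the scatter). This aromatic carbon, para to a large group, has now carried hydrogen, methoxy and fluoro on the same core, and compounds 1, 2 and 4 all read alike, so the earlier single step with methoxy now has a second, different substituent beside it. The data shown offer no measurement that would account for this sameness.

Still open, going by these compounds, is whether this carbon tolerates any group at all, since an amine, a carboxylic acid or a longer chain such as butoxy could behave quite differently from these three small groups. On these data alone, it is also open whether fluoro would read the same on another carbon of this ring.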